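Changing the Chain on the Amine Nitrogen

The compounds below may be only part of what the source reports. "The series", "measured", "known", "first", "only" and "open" are said of these compounds alone.

Compound 2 `COC(=O)CC(=O)NC1=CS(=O)(=O)O[C@@]12[C@@H](CO[Si](C)(C)C(C)(C)C)O[C@@H](n1cc(C)c(=O)n(C)c1=O)[C@@H]2O[Si](C)(C)C(C)(C)C` was tested in a functional assay on MT4 cells (Homo sapiens) (a higher number here means that more compound is tolerated, a lower number that less compound is tolerated), where it gives 11900 nM, the highest of the two numbers measured. The nearest value belongs to compound 1 `COC(=O)C(=O)CNC1=CS(=O)(=O)O[C@@]12[C@@H](CO[Si](C)(C)C(C)(C)C)O[C@@H](n1cc(C)c(=O)n(C)c1=O)[C@@H]2O[Si](C)(C)C(C)(C)C`, which gives 10300 nM in this assay, and the step of a 1.2-fold higher number from compound 1 to compound 2 (0.06 log units; within the scatter) lies within the scatter. Compound 3 `Cc1cn([C@@H]2O[C@@H]3COC(=O)[C@]3(OS(C)(=O)=O)[C@H]2O)c(=O)[nH]c1=O` gives only a limit, >= 250000 nM, in this assay; the limit of >= 250000 nM in this assay, at which 1 of the 3 values shown sits, marks where it sits. Compound 4 `Cc1cn([C@@H]2O[C@H](CO[Si](C)(C)C(C)(C)C)[C@@]3(OS(=O)(=O)C=C3NCC(=O)C(N)=O)[C@H]2O[Si](C)(C)C(C)(C)C)c(=O)n(C)c1=O` has not been measured; it differs from compound 2 by (carbamoylcarbonyl)methyl in place of ((methoxycarbonyl)methyl)carbonyl on an amine nitrogen. Within the data shown here, the only measured step bearing on this change, a 1.2-fold higher number from compound 1 to compound 2 (0.06 log units; within the scatter), was small and also sat on the amine nitrogen, so the estimated step of a 1.1-fold lower number from compound 2 to compound 4 (0.03 log units; within the scatter) is expected to stay within the scatter. Compound 4 is therefore expected to give about 11000 nM, between 5000 nM and 25000 nM.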

Compound 4, half-maximal cytotoxic concentration: 9590 nM
Beside the measured number, compound 4's estimate is 1.1-fold (0.06 log units) above it; low and high end bracket the measured number.
By their numbers in this assay, from the lowest: compounds 4, 1 and 2 (each within the scatter of the next). At a limit, above all of these: compound 3.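

In this assay, placing (carbamoylcarbonyl)methyl on the amine nitrogen gives a 1.2-fold lower number from compound 2 to compound 4 (0.09 log units; within the scatter) and so leaves the number unchanged within the scatter. Amino in place of methoxy on the carbonyl carbon gives a 1.1-fold lower number from compound 1 to compound 4 (0.03 log units; within the scatter) and shows that this chain accepts an amide end as well as a methyl ester end. Nothing measured here explains why these chains give such similar numbers.

Still open, as far as these compounds go, is whether a carboxylic acid at the end of the chain, or a longer chain, would give a number beyond the scatter. From the compounds shown here alone, a plain amine on this nitrogen remains equally open.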